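Cyano for Methyl on the Pyrazole of Compound 2

A few compounds are considered here, and "the series" means these few. Any claim that something is new, unique, unknown or untested is made for them only; others in the source may bear on it.

Compound 1, `O=C(N1CCCN(Cc2ccc(OCc3ccccc3)cc2)CC1)n1cccn1`: 960 nM
Compound 2, `Cc1cnn(C(=O)N2CCN(C(c3ccc(OCc4ccccc4)cc3)c3ccc(OCc4ccccc4)cc3)CC2)c1`: > 100000 nM

In an assay on membranes from brain for binding affinity to Monoacylglycerol lipase ABHD6 (Mus musculus), read by fluorescence, with stated times of 1 h and 30 min (a higher number here means a weaker inhibitor, a lower number a stronger inhibitor), compound 1 gives 960 nM. For compound 2 only a limit is reported, > 100000 nM. Compound 2 thus stands at the limit of > 100000 nM in this assay, at which 1 of the 2 values shown sits, with no number of its own. Compound 3, `N#Cc1cnn(C(=O)N2CCN(C(c3ccc(OCc4ccccc4)cc3)c3ccc(OCc4ccccc4)cc3)CC2)c1`, differs from compound 2 by cyano in place of methyl on an aromatic carbon. Among the compounds with values here, no measured step covers such a change here, so no direction beyond the usual scatter is known. Compound 3 is expected to give about 50000 nM, within 5000 nM to 300000 nM. This estimate means an expected step of an at least 2.0-fold lower number from compound 2 to compound 3 (0.30 log units; that floor lies within the scatter).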

Compound 3, half-maximal inhibitory concentration: 130000 nM
For compound 3 the middle estimate is 2.6-fold (0.41 log units) below the measured one, and the stated range covers the measured number.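

In this assay, within the data shown here, compound 2 has only a limit, > 100000 nM, and no step from it to compound 3 can be read. The compounds shown leave open whether changing 4-methyl-1H-pyrazol-1-yl to 4-cyano-1H-pyrazol-1-yl shifts the number at all.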